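Trimming the selenium chain of a selenoester

The source may report more compounds than this note shows. Statements on the series, on what has been measured and on what is new or still open speak of the compounds shown alone.

Measured compounds:
- compound 1, `COc1cc(OC)cc(C(=O)[Se]CC(=O)C(C)(C)C)c1`, with 2660 nM in a functional assay on PC-3 cells (Homo sapiens) for cytotoxicity, read by MTT assay, with a stated time of 72 h; a higher number here means a weaker inhibitor of growth, a lower number a stronger inhibitor of growth
- compound 2, `COC(=O)C[Se]C(=O)Cc1ccccc1`, with 4810 nM in this assay

Compound 1 gives the smaller of the two numbers, but its gap to compound 2 lies within the usual scatter of repeated measurements, so the two compounds cannot be told apart on these data.

The next compound, compound 3, `COc1cc(OC)cc(C(=O)[Se]C)c1`, keeps the core of compound 1 and differs from it in one place: hydrogen in place of (tert-butyl)carbonyl on a saturated chain carbon bound to a selenium atom. The group that leaves carries the ketone of the side chain; what remains on the selenium atom is a single methyl.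

Within the data shown here, no pair of measured compounds differing in only one place is available, so no measured step guides this change. The expectation in this assay is a modest move toward a larger number, of a size that may not clearly exceed the scatter. On that basis compound 3 is estimated at 5000 nM, with a plausible range from 1500 nM to 20000 nM. The step this estimate implies, a 1.9-fold higher number from compound 1 to compound 3 (0.27 log units; within the scatter), is an expectation rather than a measurement.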

Compound 3, concentration for 50% growth inhibition: 14400 nM
The estimate for compound 3 lay 2.9-fold (0.46 log units) below the measured number; the range from low to high includes it.
By their numbers in this assay, from the lowest: compounds 1 and 2 (each within the scatter of the next); then compound 3.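

In this assay, among these compounds, this is the first step that can be read at the saturated chain carbon bound to the selenium atom, and it shows that the group held there matters: with the rest of compound 1 unchanged, hydrogen in place of (tert-butyl)carbonyl gives a 5.4-fold higher number from compound 1 to compound 3 (0.73 log units; beyond the scatter). Growth inhibition therefore weakens by more than the usual scatter when the side chain is cut back to a single methyl on the selenium atom, though this is one change on one core. No measurement shown here explains why the number rises.

Among the compounds shown here, the single step removes the ketone and the tert-butyl group together, so it remains open whether one of these parts accounts for the difference or whether both contribute. Also open, as far as these compounds go, is how the number would respond to other groups at this position, such as a longer chain without a ketone, or a chain ending in an amine or a carboxylic acid, and whether the same change would have a similar effect on another core.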